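The source may report more compounds than this note shows. Statements on the series, on what has been measured and on what is new or still open speak of the compounds shown alone.

Compound 1 `COc1ccccc1CNc1ncnc2c1ncn2C1CCCCO1`: > 100000 nM
Compound 2 `COc1ccc(OC)c(CNc2ncnc3c2ncn3C2CCCCO2)c1`: 25400 nM
Compound 3 `COc1cc(CNc2ncnc3c2ncn3C2CCCCO2)cc(OC)c1`: > 100000 nM

Three compounds on a shared core were tested in an ADME assay on MCF7 cells (Homo sapiens) for cytotoxicity, with a stated time of 72 h; a higher number here means a weaker inhibitor, a lower number a stronger inhibitor. In this assay compound 1 gives only a limit, > 100000 nM. Compound 2 gives 25400 nM. Compound 3 again gives only a limit, > 100000 nM. Among the compounds with values here, the one measured step, an at least 3.9-fold lower number from compound 1 to compound 2 (0.59 log units; beyond the scatter), goes with methoxy in place of hydrogen on an aromatic carbon. The difference between the cores of compound 1 and compound 3 is not broken down here.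

Compound 4 `COc1cc(CNc2ncnc3c2ncn3C2CCCCO2)cc(OC)c1OC` has not yet been measured in this assay. It differs from compound 3 by methoxy in place of hydrogen on an aromatic carbon, the same kind of change as that from compound 1 to compound 2, though the surroundings differ: in compound 2 the new group sits meta to a large group and para to a methoxy group, whereas in compound 4 it sits ortho to two methoxy groups and para to a large group. Given (the limit of > 100000 nM in this assay, at which 2 of the 3 values shown sit), the starting value of compound 3 is itself only a limit. Within the data shown here, the step to compound 4 is expected to be an at least 1.4-fold lower number from compound 3 to compound 4 (0.15 log units; that floor lies within the scatter), resting on an at least 3.9-fold lower number from compound 1 to compound 2 (0.59 log units; beyond the scatter) as the only measured precedent. Compound 4 is thus estimated at 70000 nM, expected between 15000 nM and 300000 nM.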

Compound 4, half-maximal inhibitory concentration: > 100000 nM
Compound 4: only a limit was reported; the forecaster's own chance of this, stated with the estimate: 55%; middle value at least 1.4-fold (0.15 log units) from the limit.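

In this assay compound 4 gives only a limit, > 100000 nM. Compound 3 is also reported only as a limit, so no step from compound 3 to compound 4 can be read: the limit of > 100000 nM in this assay, at which 3 of the 4 values shown sit.

The compounds shown leave open whether methoxy in place of hydrogen, ortho to two methoxy groups and para to a large group, changes the number at all.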